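Methylamino for ethyl at the assay's lower limit

The source may hold more compounds than are shown below. What is called first, only, known or untested is meant among the compounds shown, and "the series" means these compounds.

- compound 1 `CN1CCN(c2cc(CN3C(=O)N(c4ccc(SC(F)(F)F)cc4)C(=O)C3(C)C)ccn2)CC1`: 0.159 ug/mL
- compound 2 `COc1ccc(CNc2cc(CN3C(=O)N(c4ccc(SC(F)(F)F)cc4)C(=O)C3(C)C)ccn2)cc1`: < 0.027 ug/mL (a limit)
- compound 3 `CCc1cc(CN2C(=O)N(c3ccc(SC(F)(F)F)cc3)C(=O)C2(C)C)ccn1`: < 0.022 ug/mL (a limit)

In a physicochemical assay for solubility, read by nephelometry (on this read-out lower numbers stand for lower solubility and higher numbers for higher solubility), compound 3 gives no number, only the limit < 0.022 ug/mL. Compound 4 `CNc1cc(CN2C(=O)N(c3ccc(SC(F)(F)F)cc3)C(=O)C2(C)C)ccn1` carries methylamino in place of ethyl on an aromatic carbon, next to the ring nitrogen (methylamino in place of ethyl on an aromatic carbon). For the measured compounds named here, two measured steps bear on this change: ethyl in place of 4-methylpiperazin-1-yl gave an at least 7.2-fold lower number from compound 1 to compound 3 (0.85 log units; beyond the scatter), and (4-methoxybenzyl)amino in place of 4-methylpiperazin-1-yl gave an at least 5.8-fold lower number from compound 1 to compound 2 (0.77 log units; beyond the scatter). Between the two lower compounds stands a step that the two limits leave unreadable from compound 2 to compound 3. Going by the values given here, a modest step to a higher number is therefore expected, with compound 1 at 0.159 ug/mL as the only measured number. The expected step is an at least 2.2-fold higher number from compound 3 to compound 4 (0.35 log units; beyond the scatter). For compound 4 the estimate is 0.05 ug/mL, with an expected range of 0.015 ug/mL to 0.2 ug/mL.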

Compound 4, solubility: 0.075 ug/mL
Compound 4: middle estimate off by 1.5-fold (0.18 log units), on the low side; low and high end bracket the measured number.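

In this assay, methylamino in place of ethyl, with the same count of heavy atoms, gives an at least 3.4-fold higher number from compound 3 to compound 4 (0.53 log units; beyond the scatter), and hydrogen in place of 4-methoxyphenyl gives an at least 2.7-fold higher number from compound 2 to compound 4 (0.44 log units; beyond the scatter). The entries for compound 2 and compound 3 are limits and not numbers, so the full size of both steps stays unread. Against 4-methylpiperazin-1-yl, methylamino gives a 2.1-fold lower number from compound 1 to compound 4 (0.33 log units; beyond the scatter).

Open, on these data alone, is whether the higher number needs the hydrogen on the nitrogen, which dimethylamino on this carbon would test. Also open, as far as these compounds go, is whether a longer chain on that nitrogen, such as ethylamino, keeps it.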